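Alkoxy chain variation on the flavanone-type series: allyloxy to ethoxy

This account rests on a few compounds, and the source may have more. Where it says the series, first, only, none or still open, it means among the compounds named here.

Measured compounds:
- compound 1, `C=CCOc1ccccc1C1CC(=O)c2ccccc2O1`, 37800 nM
- compound 2, `CCCOc1ccccc1C1CC(=O)c2ccccc2O1`, 46000 nM

Compound 1 gives 37800 nM in a functional assay on RAW264.7 cells (Mus musculus) for inhibition, read by Griess assay, with stated times of 1 h and 24 h (a higher number here means a weaker inhibitor, a lower number a stronger inhibitor), the lower of the two numbers seen so far; compound 2 sits at 46000 nM, and the two values lie within the scatter of each other, so no order can be read between them.

Compound 3, `CCOc1ccccc1C1CC(=O)c2ccccc2O1`, is not yet measured. It differs from compound 1 as follows: methyl in place of vinyl on a saturated chain carbon bound to an oxygen on an aromatic ring.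

Within the data shown here, only one measured step bears on this change. The step of a 1.2-fold higher number from compound 1 to compound 2 (0.09 log units; within the scatter) replaces the same vinyl with an ethyl at the same place, so a chain change at this position left this assay essentially unmoved. The change to compound 3 is of the same kind, a smaller saturated chain in place of the vinyl, and on this evidence no step beyond the scatter is expected for compound 3; its estimated step is a 1.1-fold higher number from compound 1 to compound 3 (0.05 log units; within the scatter).

Compound 3 is therefore expected to give about 42000 nM, with a plausible range from 20000 nM to 85000 nM.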

Compound 3, half-maximal inhibitory concentration: 38500 nM
The estimate for compound 3 lay 1.1-fold (0.04 log units) above the measured number, and the stated range covers the measured number.
By their numbers in this assay, from the lowest: compounds 1, 3 and 2 (each within the scatter of the next).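

The ethoxy compound adds a second probe of this position in this assay: methyl in place of vinyl on a saturated chain carbon bound to an oxygen on an aromatic ring gives a 1.0-fold higher number from compound 1 to compound 3 (0.01 log units; within the scatter). Among these compounds, it also adds the first comparison between two saturated chains, where hydrogen in place of methyl on a saturated chain carbon, two bonds along the chain from an oxygen on an aromatic ring, gives a 1.2-fold lower number from compound 2 to compound 3 (0.08 log units; within the scatter), so both the loss of the double bond and the trimming of the saturated chain stay within the scatter across these three compounds. No measurement is available that would explain this flat result.

The compounds shown span only small hydrocarbon chains, so it remains open whether a longer chain such as octyl, or a benzyl group, would give a value outside the scatter of these three in this assay. Also open, going by these compounds, is how a chain ending in an amine or a carboxylic acid, or a free hydroxyl in place of the ether, would read at this position.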